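Swapping a branched alkyl for phenyl on a cyanoguanidine

The source may hold more compounds than are shown below. What is called first, only, known or untested is meant among the compounds shown, and "the series" means these compounds.

Measured so far:
compound 1 `N#CN/C(=N\C1CCCCC1)Nc1ccncc1` gives 20 mg/kg
compound 2 `CC(C)C(C)(C)/N=C(\NC#N)Nc1ccncc1` gives 20 mg/kg

In a functional assay on the whole organism (blood, strain Wistar-Okamoto) with Rattus norvegicus as the target, with a stated time of 5 days (on this read-out lower numbers stand for an effect already at smaller amounts and higher numbers for an effect only at larger amounts of compound), compound 1 gives 20 mg/kg. Compound 2 stands level with it, giving 20 mg/kg in this assay; the step of no change at the digits printed from compound 1 to compound 2 (within the scatter) is within the scatter, so the two numbers cannot be told apart.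

Compound 3 `N#CN/C(=N\c1ccccc1)Nc1ccncc1` has not yet been measured. It differs from compound 2 in one place: phenyl in place of 1,1,2-trimethylpropyl on a double-bonded nitrogen. Among the compounds with values here, the only measured step that bears on this change is no change at the digits printed from compound 1 to compound 2 (within the scatter), where one saturated six-carbon group replaced another and the minimum effective dose did not move. Within the data shown here, no measured pair shows what an aromatic ring in this position does, so the expectation rests on that single step alone.

Compound 3 is therefore expected to stay close to compound 2, with a step of no change at the digits printed from compound 2 to compound 3 (within the scatter), giving an estimated 20 mg/kg with a range from 7 mg/kg to 60 mg/kg.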

Compound 3, minimum effective dose: 50 mg/kg
The estimate for compound 3 lay 2.5-fold (0.40 log units) below the measured number; measured number inside the range.
By their numbers in this assay, from the lowest: compounds 1 and 2 (each within the scatter of the next); then compound 3.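

This position is not indifferent to what it carries: in this assay the change to phenyl gives a 2.5-fold higher number from compound 2 to compound 3 (0.40 log units; beyond the scatter) and a 2.5-fold higher number from compound 1 to compound 3 (0.40 log units; beyond the scatter) even though compound 1 and compound 2 could not be told apart. A higher number here means that more compound is needed for an effect, so this modest step runs against phenyl. Phenyl has as many heavy atoms as 1,1,2-trimethylpropyl, so the step cannot be read from that count, and nothing given here explains the difference.

From the compounds shown here alone, whether the higher number belongs to phenyl alone or to aromatic rings more widely stays open. Also open, going by these compounds, is how a benzyl group, a methoxy group on the phenyl ring or a short chain such as ethyl would read on this double-bonded nitrogen.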